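This account rests on a few compounds, and the source may have more. Where it says the series, first, only, none or still open, it means among the compounds named here.

Measured compounds:
- compound 1, `Fc1ccc(C(SCCNC2CCN(Cc3ccc(C(F)(F)F)cc3)CC2)c2ccc(F)cc2)cc1`: 186 nM
- compound 2, `O=C(c1cc2ccccc2o1)N1CCC(NCCSC(c2ccc(F)cc2)c2ccc(F)cc2)CC1`: 304 nM
- compound 3, `O=C(c1ccc(F)cc1)N1CCC(NCC[S+]([O-])C(c2ccc(F)cc2)c2ccc(F)cc2)CC1`: 1440 nM

All three were tested in an assay on membranes from Cortex for displacement of a labelled ligand from Sigma non-opioid intracellular receptor 1 (Cavia porcellus), read by scintillation counting, with a stated time of 120 min; a lower number here means a stronger inhibitor, a higher number a weaker inhibitor. Compound 2 holds the second highest of the three numbers. Its nearest neighbour is compound 1, and the step of a 1.6-fold higher number from compound 1 to compound 2 (0.21 log units; within the scatter) lies within the scatter, so the two cannot be told apart. Compound 3 sits furthest away; it differs from compound 2 in two places at once, and its number is clearly higher than the value of compound 2, beyond the scatter.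

The unmeasured compound 4, `Fc1ccc(C(SCCNC2CCN(CC3CC3)CC2)c2ccc(F)cc2)cc1`, derives from compound 2 by the change (cyclopropylmethyl in place of (1-benzofuran-2-yl)carbonyl on an amine nitrogen in a ring). Among the measured compounds shown here, the only measured step that touches this position is the one from compound 1 to compound 2, where a benzyl-type group was exchanged for the benzofuranylcarbonyl group without a shift beyond the scatter. Compound 4 carries a small saturated group on that nitrogen, as compound 1 carries a non-carbonyl group there, so the step is expected to stay small: the estimate for a 1.4-fold lower number from compound 2 to compound 4 (0.14 log units; within the scatter) is a slight lowering, not beyond the scatter. Compound 4 is therefore expected to give about 220 nM in this assay, with a range from 90 nM to 550 nM.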

Compound 4, inhibition constant: 269 nM
Compound 4: the middle estimate sits 1.2-fold (0.09 log units) below what was measured; low and high end bracket the measured number.
By their numbers in this assay, from the lowest: compounds 1, 4 and 2 (each within the scatter of the next); then compound 3.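

In this assay, among the compounds shown here, the earlier compounds carried only large groups with an aromatic ring on the amine nitrogen in a ring, so they did not show whether such a ring matters at this position. Replacing (1-benzofuran-2-yl)carbonyl with cyclopropylmethyl gives a 1.1-fold lower number from compound 2 to compound 4 (0.05 log units; within the scatter) and the comparison on the other side gives a 1.4-fold higher number from compound 1 to compound 4 (0.16 log units; within the scatter) for cyclopropyl in place of 4-(trifluoromethyl)phenyl on the saturated chain carbon bound to that nitrogen. Among these three compounds, then, neither an aromatic ring, nor the carbonyl, nor the difference between the 11 heavy atoms of the group that leaves and the 4 of the group that enters moves the number beyond the scatter, and nothing given here offers an explanation for this.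

The compounds shown leave open whether this tolerance extends to the free secondary amine with only hydrogen on that nitrogen, to a longer alkyl chain or to a group carrying a carboxylic acid. Compound 3 differs from compound 2 in two places at once, so its higher number cannot be assigned to either change alone, and what each contributes remains unresolved.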